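Smaller ring on the aromatic nitrogen: compound 3 to compound 4

A few compounds are considered here, and "the series" means these few. Any claim that something is new, unique, unknown or untested is made for them only; others in the source may bear on it.

Measured in an in vitro ADME assay on microsomes from liver (Homo sapiens) for metabolic stability; a higher number here means faster removal of the compound, a lower number slower removal:
- compound 1 `CC(C)Nc1nccc(-c2c[nH]nc2-c2ccc(Cl)cc2)n1`: 0.106 mL/min/kg
- compound 2 `CC(C)Nc1nccc(-c2c[nH]nc2C2CCCNC2)n1`: 0.014 mL/min/kg
- compound 3 `Clc1ccc(-c2n[nH]cc2-c2ccnc(NC3CCCCC3)n2)cc1`: 0.156 mL/min/kg

Compound 3 has the highest of the three numbers in this assay; compound 1 is nearest to it, a gap that sits within the scatter, so the two cannot be ordered, while compound 2 is the furthest and clearly separated. Among the measured compounds shown here, the only step that moves the number beyond the scatter is a 7.6-fold lower number from compound 1 to compound 2 (0.88 log units; beyond the scatter), which is a change at the other end of the shared core and does not touch the position altered here.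

Compound 4 `Clc1ccc(-c2n[nH]cc2-c2ccnc(NC3CC3)n2)cc1` carries cyclopropyl in place of cyclohexyl on a nitrogen on an aromatic ring. For the measured compounds named here, the one measured step at this place, a 1.5-fold higher number from compound 1 to compound 3 (0.17 log units; within the scatter), stayed within the scatter when the alkyl group on that nitrogen grew from isopropyl to cyclohexyl. Shrinking it to cyclopropyl is therefore expected to give at most a small shift in this assay, if any, with the step of a 1.4-fold lower number from compound 3 to compound 4 (0.15 log units; within the scatter) estimated as one that stays within the usual scatter. For compound 4 the estimate is 0.11 mL/min/kg, expected to fall between 0.05 mL/min/kg and 0.25 mL/min/kg.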

Compound 4, clearance: 0.096 mL/min/kg
Compound 4: the middle estimate sits 1.1-fold (0.06 log units) above what was measured; the measured number falls inside the stated range.
By their numbers in this assay, from the lowest: compound 2; then compounds 4, 1 and 3 (each within the scatter of the next).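

In this assay, the group on the nitrogen on an aromatic ring now spans cyclopropyl, isopropyl and cyclohexyl, and both new steps stay within the scatter (a 1.6-fold lower number from compound 3 to compound 4 (0.21 log units; within the scatter); a 1.1-fold lower number from compound 1 to compound 4 (0.04 log units; within the scatter)). Together with the earlier isopropyl to cyclohexyl step, every pair at this place has now been read, and none separates: taking the group from 6 heavy atoms to 3 does not resolve compound 3 from compound 4 in this read-out. Among the compounds shown, the only change that moves the number beyond the scatter remains the one at the other end of the shared core (a 7.6-fold lower number from compound 1 to compound 2 (0.88 log units; beyond the scatter)). Nothing at hand accounts for this insensitivity.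

From the compounds shown here alone, all three groups on that nitrogen contain carbon only, so it remains open whether a group bearing a heteroatom, such as a hydroxyethyl chain, a carboxylic acid or an amine, or a longer chain such as n-hexyl, would stay within the scatter too. Going by these compounds, it is also open whether the same insensitivity holds when piperidin-3-yl replaces 4-chlorophenyl on the core.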